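From amino to hydroxymethyl: one swap, one open question

The source may report more compounds than this note shows. Statements on the series, on what has been measured and on what is new or still open speak of the compounds shown alone.

In an ADME assay on TZM cells (Homo sapiens) for cytotoxicity, read by XTT assay, with a stated time of 4 days (on this read-out lower numbers stand for higher toxicity in this test and higher numbers for lower toxicity in this test), compound 3 `Cc1cc(CCC#N)cc(C)c1Oc1cc(Nc2ccc(C#N)cc2)c(N)cc1N` gives > 25000 nM. This is a limit of the assay and not a number, so compound 3 has no exact position on the scale.

Compound 4 `Cc1cc(CCC#N)cc(C)c1Oc1cc(Nc2ccc(C#N)cc2)c(N)cc1CO` alters one group of that structure: hydroxymethyl in place of amino on an aromatic carbon. In words, hydroxymethyl takes the place of amino on an aromatic carbon, para to a (4-cyanophenyl)amino group.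

One measured step involves this same carbon: an at least 1.7-fold higher number from compound 1 to compound 3 (0.24 log units; that floor lies within the scatter). There, amino stands in place of carboxy, and the size of that step is known only as a floor within the scatter. Compound 1 `Cc1cc(CCC#N)cc(C)c1Oc1cc(Nc2ccc(C#N)cc2)c(N)cc1C(=O)O` gives 14300 nM. Also carrying hydroxymethyl, though with a further difference elsewhere, compound 2 `Cc1cc(CO)cc(C)c1Oc1cc(Nc2ccc(C#N)cc2)c(N)cc1CO` gives 15900 nM, within the scatter of the value for compound 1.

Compound 2, at 15900 nM, is the closest guide, so a measurable number in that region is expected. This suggests an estimated at least 1.3-fold lower number from compound 3 to compound 4 (0.14 log units; that floor lies within the scatter), a small move toward a lower number that may not exceed the scatter. For compound 4 the estimated value is 18000 nM, with an expected range from 9000 nM to 32000 nM. Another limit remains possible for compound 4.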

Compound 4, half-maximal cytotoxic concentration: > 23800 nM
Compound 4: a limit, no number; the forecaster's own chance of this, stated with the estimate: 35%; middle value at least 1.3-fold (0.12 log units) from the limit.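

In this assay, compound 4 gives only a limit of the assay and not a number: the limit of > 23800 nM in this assay, at which 1 of the 4 values shown sits. Compound 3 also stands at a limit, so the step between these two compounds cannot be read, and swapping amino for hydroxymethyl on this carbon has no measured size: the limit of > 25000 nM in this assay, at which 1 of the 4 values shown sits. The new information comes from the two readable steps, with hydroxymethyl in place of carboxy on the aromatic carbon giving an at least 1.6-fold higher number from compound 1 to compound 4 (0.22 log units; that floor lies within the scatter), and cyanomethyl in place of hydroxy on the saturated chain carbon giving an at least 1.4-fold higher number from compound 2 to compound 4 (0.17 log units; that floor lies within the scatter); each is only a floor, so the true size of either change may be larger.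

The compounds shown leave open how a primary amide or a methoxymethyl group on this same carbon would read in this assay, and whether either would give a number or another limit. They also leave open whether a longer chain ending in hydroxy, on the saturated side of the molecule, would give a number in this test.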